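The source may report more compounds than this note shows. Statements on the series, on what has been measured and on what is new or still open speak of the compounds shown alone.

Working notes on the series in a functional assay on the whole organism (strain C57B/6) with Mus musculus as the target, in the maximal electroshock model; a higher number here means that more compound is needed for the effect, a lower number that less compound is needed.

Compound 1, `CCCCCCOc1ccc(-n2cnnc2CC)cc1`, gives 13.2 mg/kg in this assay. Compound 3, `CCCCCCOc1ccc(-n2cnnc2-c2ccc(Cl)cc2)cc1`, gives 19.7 mg/kg; the step of a 1.5-fold higher number from compound 1 to compound 3 (0.17 log units; within the scatter) leaves the two within the scatter of each other, so the numbers of compound 1 and compound 3 cannot be ordered. Compound 2, `CCCCCCCc1nncn1-c1ccc(OCCCCCC)cc1`, yields only a limit of the assay in this assay, > 40 mg/kg. That limit is the one at the limit of > 40 mg/kg in this assay, at which 1 of the 3 values shown sits. Of the two numbers shown, compound 1 has the lowest; the remaining value is a limit.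

Compound 4, `CCCCCCOc1ccc(-n2cnnc2Cc2ccccc2)cc1`, is not yet measured in this assay. It differs from compound 1 by phenyl in place of methyl on a saturated chain carbon bound to an aromatic carbon. Among the measured compounds shown here, two measured steps bear on it: the chain extension at the same saturated carbon, an at least 3.0-fold higher number from compound 1 to compound 2 (0.48 log units; beyond the scatter), and the aryl group placed on the core in a 1.5-fold higher number from compound 1 to compound 3 (0.17 log units; within the scatter). The former moved the number up beyond the scatter, the latter stayed within it. A modest upward step is therefore expected, a 1.7-fold higher number from compound 1 to compound 4 (0.22 log units; within the scatter), with some chance that only a limit is returned. Compound 4 is estimated at 22 mg/kg, within 10 mg/kg to 45 mg/kg.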

Compound 4, dose for half-maximal effect: 19 mg/kg
For compound 4 the middle estimate is 1.2-fold (0.06 log units) above the measured one; low and high end bracket the measured number.
By their numbers in this assay, from the lowest: compounds 1, 4 and 3 (each within the scatter of the next). At a limit, above all of these: compound 2.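

At the saturated chain carbon bound to an aromatic carbon in this assay, phenyl in place of methyl gives a 1.4-fold higher number from compound 1 to compound 4 (0.16 log units; within the scatter), and benzyl in place of 4-chlorophenyl on an aromatic carbon gives a 1.0-fold lower number from compound 3 to compound 4 (0.02 log units; within the scatter), so neither change can be read as moving the number. Phenyl in place of hexyl at that same carbon gives an at least 2.1-fold lower number from compound 2 to compound 4 (0.32 log units; beyond the scatter), so the rise seen with the heptyl chain of compound 2 does not follow from any larger group at this carbon, since phenyl does not reproduce it. Compound 2 stands only at a limit of the assay: the limit of > 40 mg/kg in this assay, at which 1 of the 4 values shown sits.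

Left open is how an amine or a carboxylic acid at this carbon would read. Also open, as far as these compounds go, is whether a butyl chain stays with compound 1, and how a 4-chlorobenzyl group compares with compound 4.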